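Thiazole acetic acids: pyrrolidinyl in place of hydroxy

The compounds below may be only part of what the source reports. "The series", "measured", "known", "first", "only" and "open" are said of these compounds alone.

Compound 1 `O=C(O)Cc1sc(C(c2ccc(F)cc2)c2ccc(F)cc2)nc1-c1ccccc1` gives 16 nM in an in vitro assay on HEK385-7 cells for displacement of a labelled ligand from prostaglandin D2 receptor 2 (Homo sapiens); on this read-out lower numbers stand for stronger inhibition and higher numbers for weaker inhibition. Within the data shown here, compound 2 `O=C(O)Cc1sc(C(c2ccc(F)cc2)c2ccc(F)cc2)nc1-c1ccnc(O)c1` gives 68 nM in this assay, and the single computed step, a 4.3-fold higher number from compound 1 to compound 2 (0.63 log units; beyond the scatter), is beyond the scatter. Among the measured compounds shown here, compound 2 thus stands at the higher of the two numbers so far; its only neighbour is compound 1.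

Compound 3 `O=C(O)Cc1sc(C(c2ccc(F)cc2)c2ccc(F)cc2)nc1-c1ccnc(N2CCCC2)c1` differs from compound 2 by pyrrolidin-1-yl in place of hydroxy on an aromatic carbon. For the measured compounds named here, no measured step covers this exchange on the pyridine ring; the only step in hand, a 4.3-fold higher number from compound 1 to compound 2 (0.63 log units; beyond the scatter), concerns the arrival of the hydroxypyridinyl ring itself and bears on compound 3 only indirectly. The hydroxy group that accompanied the weaker number is removed, so a number nearer to that of compound 1 is plausible, but the uncertainty is large. Compound 3 is therefore estimated at 40 nM in this assay, with a range from 10 nM to 160 nM. The expected step is a 1.7-fold lower number from compound 2 to compound 3 (0.23 log units; within the scatter).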

Compound 3, half-maximal inhibitory concentration: 230 nM
For compound 3 the middle estimate is 5.8-fold (0.76 log units) below the measured one, outside the stated range (above it).
By their numbers in this assay, from the lowest: compound 1; then compound 2; then compound 3.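

In this assay, pyrrolidin-1-yl next to the ring nitrogen gives a 3.4-fold higher number from compound 2 to compound 3 (0.53 log units; beyond the scatter) and so does not recover ground lost by the hydroxy compound; at this place, hydroxy is the better of the two groups. Set against the phenyl ring, the 2-(pyrrolidin-1-yl)pyridin-4-yl ring shows a 14-fold higher number from compound 1 to compound 3 (1.16 log units; beyond the scatter) and leaves compound 3 the weakest of the three. No supporting data bear on why either step occurs.

Still open, as far as these compounds go, is how much of the loss belongs to the ring nitrogen and how much to the group placed next to it; an unsubstituted pyridin-4-yl ring would separate the two. Also open, from the compounds shown here alone, is whether a primary amine or a methoxy group at this place would fall nearer to hydroxy or to pyrrolidin-1-yl.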